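The compounds below may be only part of what the source reports. "The series", "measured", "known", "first", "only" and "open" are said of these compounds alone.

Working notes on the series, tracked in a functional assay on NCI-H661 cells (Homo sapiens) for antiproliferative activity, read by MTT assay, with a stated time of 72 h; on this read-out lower numbers stand for stronger inhibition of growth and higher numbers for weaker inhibition of growth. For the measured compounds named here, compound 1 `O=C(COc1ccc2c(=O)cc(-c3ccccc3)oc2c1)Nc1ccc2ccccc2c1` is the first member. In this assay compound 1 is reported only as a limit of the assay, > 10000 nM. Compound 2 `O=C(COc1c(-c2ccccc2)oc2ccccc2c1=O)Nc1ccccc1` is the second member. In this assay compound 2 likewise returns only a limit of the assay, > 10000 nM. Going by the values given here, compound 2 therefore stands at the same limit as the one other value shown, and this is all that is known: both values sit at the limit of > 10000 nM in this assay, at which 2 of the 2 values shown sit, so no numbered potency exists anywhere, and no step between measured compounds can be read. Compound 3 `O=C(COc1c(-c2ccccc2)oc2ccccc2c1=O)Nc1ccc(-c2ccccc2)cc1` differs from compound 2 by phenyl in place of hydrogen on an aromatic carbon, para to a large group. Among the compounds with values here, there is no measured step to scale this change against. With both measured compounds at the limit, the expected step from compound 2 to compound 3 in this assay is none beyond the scatter, and the estimated step is a step that the limit leaves unreadable from compound 2 to compound 3. Compound 3 is therefore expected to give about 15000 nM, within a range from 4000 nM to 60000 nM, most likely reported again as a limit only.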

Compound 3, concentration for 50% growth inhibition: > 10000 nM
Compound 3: a limit, no number; the forecaster's own chance of this, stated with the estimate: 70%; the middle value does not contradict the limit.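

Compound 3 is reported only as a limit of the assay, > 10000 nM. Compound 2 also stands at a limit, so no step from compound 2 to compound 3 can be read: the limit of > 10000 nM in this assay, at which 3 of the 3 values shown sit.

The compounds shown leave open whether any member of the series gives a numbered potency in this assay.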